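Three groups on one aromatic carbon, a fourth expected

The source may report more compounds than this note shows. Statements on the series, on what has been measured and on what is new or still open speak of the compounds shown alone.

Measured so far:
Compound 1, `Cc1cc(Br)c(S(C)(=O)=O)cc1C(=O)N=C(N)N`, in a functional assay for inhibition of sodium/hydrogen exchanger (Oryctolagus cuniculus) (on this read-out lower numbers stand for stronger inhibition and higher numbers for weaker inhibition), gives 12 nM.
Compound 2, `Cc1cc(-c2ccccc2)c(S(C)(=O)=O)cc1C(=O)N=C(N)N`, in this assay gives 19 nM.
Compound 3, `Cc1cc(N2CCCC2)c(S(C)(=O)=O)cc1C(=O)N=C(N)N`, in this assay gives 11 nM.

Compound 3 has the lowest of the three numbers shown, yet the steps leading to it, a 1.1-fold lower number from compound 1 to compound 3 (0.04 log units; within the scatter) and a 1.7-fold lower number from compound 2 to compound 3 (0.24 log units; within the scatter), both stay within the scatter, so the three compounds cannot be told apart on these data.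

Compound 4, `Cc1cc(Nc2ccccc2)c(S(C)(=O)=O)cc1C(=O)N=C(N)N`, is the next compound, and it differs from compound 3 by anilino in place of pyrrolidin-1-yl on an aromatic carbon. Going by the values given here, the two earlier exchanges at this same aromatic carbon are the steps that bear on it: bromo gave way to pyrrolidin-1-yl in a 1.1-fold lower number from compound 1 to compound 3 (0.04 log units; within the scatter), and phenyl gave way to pyrrolidin-1-yl in a 1.7-fold lower number from compound 2 to compound 3 (0.24 log units; within the scatter). Neither moved the number beyond the scatter. Among the compounds with values here, no step towards anilino has been measured, so the expectation rests on those two exchanges alone.

Compound 4 is therefore expected to show no step beyond the scatter in this assay, with an estimated value of 15 nM in the range 6 nM to 40 nM.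

The estimated step from compound 3 to compound 4 is a 1.4-fold higher number from compound 3 to compound 4 (0.13 log units; within the scatter), expected because the earlier exchanges a 1.1-fold lower number from compound 1 to compound 3 (0.04 log units; within the scatter) and a 1.7-fold lower number from compound 2 to compound 3 (0.24 log units; within the scatter) stayed within the scatter.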

Compound 4, half-maximal inhibitory concentration: 21 nM
Compound 4: middle estimate off by 1.4-fold (0.15 log units), on the low side, and the stated range covers the measured number.
By their numbers in this assay, from the lowest: compounds 3, 1, 2 and 4 (each within the scatter of the next).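

Unlike bromo, phenyl and pyrrolidin-1-yl, anilino carries a hydrogen-bond donor, yet in this assay all three steps to it stay within the scatter: a 1.9-fold higher number from compound 3 to compound 4 (0.28 log units; within the scatter), a 1.1-fold higher number from compound 2 to compound 4 (0.04 log units; within the scatter) and a 1.8-fold higher number from compound 1 to compound 4 (0.24 log units; within the scatter). This aromatic carbon, ortho to a methylsulfonyl group, has now held four different groups with no step beyond the scatter, so none of the four can be ranked above another. Nothing measured here gives a reason for this sameness.

Going by these compounds, it remains open whether a carboxylic acid, a primary amine or a longer alkyl chain on this carbon would also stay within the scatter. Also open, on these data alone, is whether the same holds with a group other than methyl on the shared core, as all four compounds keep that methyl group.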